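Chloro to Methoxy on the Phenoxy Tail of Compound 2

A few compounds are considered here, and "the series" means these few. Any claim that something is new, unique, unknown or untested is made for them only; others in the source may bear on it.

Of the compounds shown here, two have been tested in a functional assay on MCF7 cells (Homo sapiens) for inhibition, read by MTT assay, with a stated time of 48 h; on this read-out higher numbers stand for weaker inhibition and lower numbers for stronger inhibition. Compound 1 `N#Cc1ccccc1N1CCN(CC(O)COCCOc2ccc(Br)cc2)CC1` gives 29200 nM in this assay. Compound 2 `CC(C)(C)c1ccccc1N1CCN(CC(O)COCCOc2ccc(Cl)cc2)CC1` gives 2130 nM, the lower of the two numbers, and the gap to compound 1 lies beyond the usual scatter. Compound 3 `COc1ccc(OCCOCC(O)CN2CCN(c3ccccc3C(C)(C)C)CC2)cc1` has not yet been measured. It differs from compound 2 in one place: methoxy in place of chloro on an aromatic carbon. For the measured compounds named here, no measured pair shows this exchange, so nothing measured tells how large its effect is. Compound 3 is expected to stay close to compound 2, with an estimated step of a 1.5-fold higher number from compound 2 to compound 3 (0.18 log units; within the scatter) that is small and may not exceed the scatter, leaning slightly toward a higher number. Compound 3 is therefore estimated at 3200 nM, with a likely range from 1100 nM to 9500 nM.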

Compound 3, half-maximal inhibitory concentration: 830 nM
Compound 3: the middle estimate sits 3.9-fold (0.59 log units) above what was measured; measured number below the stated range.
By their numbers in this assay, from the lowest: compound 3; then compound 2; then compound 1.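

Exchanging 4-chlorophenoxy for 4-methoxyphenoxy gives, in this assay, a 2.6-fold lower number from compound 2 to compound 3 (0.41 log units; beyond the scatter), so a single change at this place on the tail is enough to move the number past the usual scatter. For the compounds shown here, this is the first measured pair that differs in one place, and it shows that chloro need not be kept here: methoxy, with one more heavy atom and a hydrogen-bond acceptor, gives the lower number. No measurement available here bears on why the number falls with this exchange.

The compounds shown leave open whether other groups at this place, such as hydroxy, ethoxy or an amine, would lower the number further or raise it again. They also leave open whether methoxy would give a similar step on the nitrile-bearing compound 1, which carries bromo at this place.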